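From 2-Chlorophenyl to 2-Chloropyridin-3-yl on the Amide Carbonyl

The source may hold more compounds than are shown below. What is called first, only, known or untested is meant among the compounds shown, and "the series" means these compounds.

Compound 1 `O=C(Nc1ccc(Cl)c(-c2nnc3c(Cl)cccn23)c1)c1ccccc1` in a functional assay on HeLa cells (Homo sapiens) for antiproliferative activity, read by MTT assay, with a stated time of 72 h (on this read-out lower numbers stand for stronger inhibition and higher numbers for weaker inhibition), gives > 100000 nM, a limit of the assay.
Compound 2 `O=C(Nc1ccc(Cl)c(-c2nnc3c(Cl)cccn23)c1)c1ccccc1Cl` in this assay gives > 100000 nM, also a limit of the assay.

Compound 2 thus stands at the limit of > 100000 nM in this assay, at which 2 of the 2 values shown sit. The step that the two limits leave unreadable from compound 1 to compound 2 lies between two limits and cannot be read. Compound 3 `O=C(Nc1ccc(Cl)c(-c2nnc3c(Cl)cccn23)c1)c1cccnc1Cl` differs from compound 2 by 2-chloropyridin-3-yl in place of 2-chlorophenyl on a carbonyl carbon. For the measured compounds named here, the one measured step concerns another part of the molecule and has no readable size, so no movement beyond the scatter is expected in this assay, and the step of a number no higher from compound 2 to compound 3 (the limit leaves the size open) is estimated as none. Compound 3 is therefore estimated at 100000 nM, within 30000 nM to 300000 nM.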

Compound 3, half-maximal inhibitory concentration: 87500 nM
Compound 3: middle estimate off by 1.1-fold (0.06 log units), on the high side, and the stated range covers the measured number.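

In this assay, compound 3 is the first shown to give a number rather than a limit, which places 2-chloropyridin-3-yl on a carbonyl carbon within reach of measurement. The readings are an at least 1.1-fold lower number from compound 2 to compound 3 (0.05 log units; that floor lies within the scatter) and an at least 1.1-fold lower number from compound 1 to compound 3 (0.05 log units; that floor lies within the scatter), so no gain beyond the scatter is shown. The step from compound 1 to compound 2 cannot be read, and the true size of both new steps stays open, with compound 2 still at a limit of the assay: the limit of > 100000 nM in this assay, at which 2 of the 3 values shown sit.

Going by these compounds, whether an amine or a carboxylic acid on the ring held by that carbonyl carbon would give a clearly lower number remains open. So does the effect of any change on the shared core.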